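Cytotoxicity notes on a chloropurine benzyl chloride series

The compounds below may be only part of what the source reports. "The series", "measured", "known", "first", "only" and "open" are said of these compounds alone.

Measured so far:
compound 1 `ClCc1ccc(Cn2cnc3c(Cl)ncnc32)cc1`: 51300 nM
compound 2 `ClCc1cccc(Cn2cnc3c(Cl)ncnc32)c1`: 79400 nM
compound 3 `ClCc1cccc(Cn2cnc3c(Cl)nc(Cl)nc32)c1`: 52500 nM

All three numbers come from a functional assay on A549 cells (Homo sapiens) for cytotoxicity, read by sulforhodamine B assay, with a stated time of 48 h; a lower number here means that less compound is tolerated, a higher number that more compound is tolerated. Compound 1 gives the smallest of them, though its gaps to compound 3 and to compound 2 both lie within the scatter, so no order among the three is established.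

Compound 4 `ClCc1ccc(Cn2cnc3c(Cl)nc(Cl)nc32)cc1` is not yet measured. Compared with compound 1 it carries chloro in place of hydrogen on an aromatic carbon. Among the compounds with values here, the same swap on the isomeric pair is the one measured step that bears on it: a 1.5-fold lower number from compound 2 to compound 3 (0.18 log units; within the scatter). In this assay no step beyond the scatter is therefore expected from compound 1 to compound 4; a slight lowering at most. Compound 4 is expected at 40000 nM, with a range of 20000 nM to 85000 nM. The expected step is a 1.3-fold lower number from compound 1 to compound 4 (0.11 log units; within the scatter).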

Compound 4, concentration lethal to 50% of the cells: 74100 nM
For compound 4 the middle estimate is 1.9-fold (0.27 log units) below the measured one, and the stated range covers the measured number.
By their numbers in this assay, from the lowest: compounds 1, 3, 4 and 2 (each within the scatter of the next).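

At the carbon between two ring nitrogen atoms, chloro in place of hydrogen gives a 1.4-fold higher number from compound 1 to compound 4 (0.16 log units; within the scatter) in this assay. With this second core, the change shows no step beyond the scatter on either core and no shared direction: the same change on two cores in this assay, a 1.5-fold lower number (0.18 log units; within the scatter) from compound 2 to compound 3 and a 1.4-fold higher number (0.16 log units; within the scatter) from compound 1 to compound 4, 2.2-fold (0.34 log units) apart, within the scatter of two such steps

From the compounds shown here alone, whether a methoxy group or an amine at this position would give a step beyond the scatter remains open. All compounds shown carry the chloromethyl group, and what a hydroxymethyl group in its place would give is also open.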